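Cyclohexyl for propyl on the amine nitrogen

The source may hold more compounds than are shown below. What is called first, only, known or untested is meant among the compounds shown, and "the series" means these compounds.

In a functional assay on CHO-K1 cells (Cricetulus griseus) for inhibition, read by sulforhodamine B assay, with a stated time of 72 h (a higher number here means a weaker inhibitor, a lower number a stronger inhibitor), compound 1 (`CCCNC(=C\C(=O)/C=C/c1ccc(O)c(OC)c1)/C=C/c1ccc(O)c(OC)c1`) reads > 25000 nM as a limit of the assay and not a number. Compound 3 (`COc1cc(/C=C/C(=O)CC(=O)/C=C/c2ccc(OC(C)=O)c(OC)c2)ccc1OC(C)=O`) reads > 25000 nM as a limit as well. Going by the values given here, compound 2 (`CC(C)CNC(=C\C(=O)/C=C/c1ccc(O)cc1)/C=C/c1ccc(O)cc1`) gives 23700 nM as the only true number in the set. Compound 1 thus stands at the limit of > 25000 nM in this assay, at which 2 of the 3 values shown sit, and offers no exact starting point.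

Compound 4 (`COc1cc(/C=C/C(=O)/C=C(/C=C/c2ccc(O)c(OC)c2)NC2CCCCC2)ccc1O`) keeps the core of compound 1 and changes one group: cyclohexyl in place of propyl on an amine nitrogen with cyclohexyl in place of propyl on an amine nitrogen. Among the compounds with values here, no pair of measured compounds differs in one place only, so nothing measured in this assay gives a direct guide to the size of this step. Within the data shown here, compound 2 at 23700 nM shows only that a number can be reached within this set. A modest move towards stronger inhibition is therefore expected, and a result within the scatter or at the limit would be no surprise. The estimated step of an at least 1.3-fold lower number from compound 1 to compound 4 (0.14 log units; that floor lies within the scatter) is therefore small. For compound 4 the expected value is 18000 nM with an estimated range from 7000 nM to 25000 nM in this read-out.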

Compound 4, half-maximal inhibitory concentration: > 25000 nM
Compound 4 gave a limit, no number (the forecaster's own chance of this, stated with the estimate: 40%); middle value at least 1.3-fold (0.14 log units) away from the limit.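

In this assay compound 4 reads > 25000 nM as a limit of the assay and not a number. Compound 1 is also a limit, so no step can be read for cyclohexyl in place of propyl, with both compounds at the same limit: the limit of > 25000 nM in this assay, at which 3 of the 4 values shown sit.

The compounds shown leave open how cyclohexyl and propyl on the amine nitrogen truly compare in strength of inhibition.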